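From Phenyl to Propanoyl: A Step Hidden Behind Limits

The source may hold more compounds than are shown below. What is called first, only, known or untested is meant among the compounds shown, and "the series" means these compounds.

In a toxicity assay on NIH3T3 cells (Mus musculus) for cytotoxicity, read by resazurin assay (a higher number here means that more compound is needed for the effect, a lower number that less compound is needed), compound 3 (`c1ccc(-c2ccc(Cn3cncc3CNc3ccc(-c4ccccc4)c(-c4ccccc4)c3)cc2)cc1`) gives > 10000 nM, which is a limit and not a number. Two relatives share its core and differ from it at one place on an aromatic carbon. Compound 1 (`Clc1ccc(NCc2cncn2Cc2ccc(-c3ccccc3)cc2)cc1-c1ccccc1`), with chloro at that place, gives > 1000 nM, again only a limit. Compound 2 (`O=C(c1ccc(NCc2cncn2Cc2ccc(-c3ccccc3)cc2)cc1-c1ccccc1)N1CCCCC1`), with (piperidin-1-yl)carbonyl there, gives > 1000 nM, also only a limit.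

Compound 4 (`CCC(=O)c1ccc(NCc2cncn2Cc2ccc(-c3ccccc3)cc2)cc1-c1ccccc1`) changes compound 3 at the same place, with propanoyl in place of phenyl on an aromatic carbon. The measured changes at this place offer no size to build on, for the data show only a step that the two limits leave unreadable from compound 1 to compound 2, a step that the two limits leave unreadable from compound 1 to compound 3 and a step that the two limits leave unreadable from compound 2 to compound 3. The closest guide is compound 2, whose group also holds a carbonyl and whose limit is > 1000 nM. A move toward a lower number is therefore expected, although its size is uncertain and a limit may again be all that is reported. In this assay, the estimated value for compound 4 is 4000 nM, with an expected range from 1000 nM to 20000 nM. The expected change is an at least 2.5-fold lower number from compound 3 to compound 4 (0.39 log units; beyond the scatter).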

Compound 4, half-maximal effective concentration: > 10000 nM
Compound 4: no number, only a limit; the forecaster's own chance of this, stated with the estimate: 75%; middle value at least 2.5-fold (0.39 log units) from the limit.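

In this assay compound 4 gives > 10000 nM, which is a limit and not a number. The steps from compound 1, compound 2 and compound 3 to compound 4 cannot be read, and no size can be given for any of them. The compounds shown leave open how much of each is needed for the effect, and whether the groups at this place differ at all.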